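The compounds below may be only part of what the source reports. "The series", "measured", "known", "first", "only" and "open" are said of these compounds alone.

Of the compounds shown here, three built on one shared core have been measured in an assay on isolated protein for inhibition of Amine oxidase [flavin-containing] B (Homo sapiens); a higher number here means a weaker inhibitor, a lower number a stronger inhibitor. Compound 1 `C#CCNC1CCc2c(SCCc3cccc(Br)c3)cccc21` gives 30500 nM, compound 2 `C#CCNC1CCc2c(SCCc3ccc(F)c(F)c3)cccc21` gives 3240 nM, and compound 3 `C#CCNC1CCc2c(SCCc3ccc(OC)cc3)cccc21` gives 62000 nM. Compound 3 thus stands at the highest number of the three: the step of a 2.0-fold higher number from compound 1 to compound 3 (0.31 log units; beyond the scatter) is modest, whereas the step of a 19-fold higher number from compound 2 to compound 3 (1.28 log units; beyond the scatter) is large, and between the other two the step of a 9.4-fold lower number from compound 1 to compound 2 (0.97 log units; beyond the scatter) is also beyond the scatter.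

Compound 4 `C#CCNC1CCc2c(SCCc3cccc(F)c3)cccc21` has not yet been measured. It differs from compound 3 by 3-fluorophenyl in place of 4-methoxyphenyl on a saturated chain carbon, two bonds along the chain from a sulfur. Among the compounds with values here, two measured steps bear on this change. Read in reverse, a 2.0-fold higher number from compound 1 to compound 3 (0.31 log units; beyond the scatter) shows that a 3-bromophenyl in this place lowered the number only a little, while a 19-fold higher number from compound 2 to compound 3 (1.28 log units; beyond the scatter), read in reverse, shows that a 3,4-difluorophenyl lowered it a great deal. The 3-fluorophenyl of compound 4 carries a single substituent on the ring like the 3-bromophenyl of compound 1, yet that substituent is fluorine as in the 3,4-difluorophenyl of compound 2. The author therefore expects a downward step for compound 4 of about a 5.2-fold lower number from compound 3 to compound 4 (0.71 log units; beyond the scatter), lying between those two reversed steps. Compound 4 is accordingly estimated at 12000 nM, with a likely range from 3000 nM to 45000 nM.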

Compound 4, half-maximal inhibitory concentration: 4300 nM
Estimate against measurement, compound 4: 2.8-fold (0.45 log units) above; low and high end bracket the measured number.
By their numbers in this assay, from the lowest: compounds 2 and 4 (each within the scatter of the next); then compound 1; then compound 3.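

In this assay, the step of a 14-fold lower number from compound 3 to compound 4 (1.16 log units; beyond the scatter) places the 3-fluorophenyl with the strongest inhibitors of this set, and a 1.3-fold higher number from compound 2 to compound 4 (0.12 log units; within the scatter) shows that hydrogen in place of fluoro on an aromatic carbon makes no difference beyond the scatter, so the second fluorine of the 3,4-difluorophenyl is not needed to reach this level. Within the data shown here, the step of a 7.1-fold lower number from compound 1 to compound 4 (0.85 log units; beyond the scatter) isolates what the earlier compounds could not: with a single substituent on the ring in both compounds, fluoro in place of bromo on an aromatic carbon is enough for a clear drop, so the identity of the halogen matters here and not only the number of substituents. No measurement given here explains why these groups differ.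

The compounds shown leave open whether the high number of compound 3 belongs to the methoxy group itself or to where it sits on the ring, which a 3-methoxyphenyl would test. They also leave open how a 3-chlorophenyl, a 4-fluorophenyl or an unsubstituted phenyl would fall, and whether a longer chain to the ring would keep the low numbers of the fluorinated compounds.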